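This account rests on a few compounds, and the source may have more. Where it says the series, first, only, none or still open, it means among the compounds named here.

Measured in a functional assay on HCT-15 cells (Homo sapiens) for antiproliferative activity, read by sulforhodamine B assay, with a stated time of 48 h; on this read-out higher numbers stand for weaker inhibition and lower numbers for stronger inhibition:
- compound 1 `O=C(NCCCNc1cc(-c2cn(-c3ccccc3)nc2-c2cccc(O)c2)ccn1)Nc1ccc(F)cc1` gives 940 nM
- compound 2 `O=C(NCCCNc1cc(-c2cn(-c3ccccc3)nc2-c2cccc(O)c2)ccn1)Nc1cccc(C(F)(F)F)c1` gives 1060 nM

Going by the values given here, compound 1 cannot be separated from the only other measured compound, as the one available step lies within the scatter (a 1.1-fold higher number from compound 1 to compound 2 (0.05 log units; within the scatter)). Compound 3 `COc1cccc(-c2nn(-c3ccccc3)cc2-c2ccnc(NCCCNC(=O)Nc3ccc(F)cc3)c2)c1` replaces the 3-hydroxyphenyl of compound 1 with 3-methoxyphenyl (methyl in place of hydrogen on an oxygen on an aromatic ring). Among the compounds with values here, that measured step concerns an amide-type nitrogen, so no measured pair tests this change on the oxygen. No direction is therefore expected, nor any shift beyond the scatter (a 1.3-fold higher number from compound 1 to compound 3 (0.11 log units; within the scatter)). For compound 3 the estimated value is 1200 nM, with an expected range from 400 nM to 3500 nM.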

Compound 3, half-maximal inhibitory concentration: 7640 nM
Compound 3: the middle estimate sits 6.4-fold (0.80 log units) below what was measured, and the stated range ends below it.
By their numbers in this assay, from the lowest: compounds 1 and 2 (each within the scatter of the next); then compound 3.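

In this assay, going by these compounds alone, the oxygen on the aromatic ring is the first place where a single change moves the number beyond the scatter: methyl in place of hydrogen gives an 8.1-fold higher number from compound 1 to compound 3 (0.91 log units; beyond the scatter), so weaker inhibition. The earlier step, on an amide-type nitrogen, separated nothing. No measurement at hand bears on the reason for this shift.

From the compounds shown here alone, how an amine or an ethoxy group would read at this place stays open. So does whether hydroxy to methoxy costs the same alongside the 3-(trifluoromethyl)phenyl of compound 2.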